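The source may report more compounds than this note shows. Statements on the series, on what has been measured and on what is new or still open speak of the compounds shown alone.

Measured in a functional assay on MCF7 cells (Homo sapiens) for antiproliferative activity, read by MTT assay, with a stated time of 72 h; on this read-out lower numbers stand for stronger inhibition and higher numbers for weaker inhibition:
compound 1, `CCN(CC)CCNc1cc(C)c2cc(NC(=O)c3ccc(Cl)c(Cl)c3)ccc2n1`: 1420 nM
compound 2, `CCN1CCN(c2cc(C)c3cc(NC(=O)c4ccccc4C)ccc3n2)CC1`: 10900 nM
compound 3, `CCN1CCN(c2cc(C)c3cc(NC(=O)c4cccc(Br)c4)ccc3n2)CC1`: 11600 nM

Compound 1 has the lowest number of the three; compound 2 is nearest and compound 3 furthest, and both gaps lie beyond the scatter. Compounds 2 and 3 share the same side chain and differ only in the aryl group on the carbonyl carbon: a 1.1-fold higher number from compound 2 to compound 3 (0.03 log units; within the scatter).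

Compound 4, `Cc1cc(N2CCN(C(C)C)CC2)nc2ccc(NC(=O)c3ccc(Cl)c(Cl)c3)cc12`, keeps the amide group of compound 1 and alters the side chain: 4-isopropylpiperazin-1-yl in place of (2-(diethylamino)ethyl)amino on an aromatic carbon. Going by the values given here, no measured step covers this side-chain exchange alone. Among the compounds with values here, the one step recorded, from compound 2 to compound 3, concerns the amide group and is within the scatter, so it says nothing directly about the side chain. Within the data shown here, compounds 2 and 3 carry a ring-containing side chain resembling the one entering compound 4, yet their higher numbers relative to compound 1 reflect changes in both the side chain and the amide, so the two contributions cannot be separated. The step expected in this assay is therefore toward a higher number, of uncertain size, a 2.5-fold higher number from compound 1 to compound 4 (0.39 log units; beyond the scatter). Compound 4 is estimated at 3500 nM, with a range from 1200 nM to 11000 nM.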

Compound 4, half-maximal inhibitory concentration: 1710 nM
Compound 4: middle estimate off by 2.0-fold (0.31 log units), on the high side, within the range that was stated.
By their numbers in this assay, from the lowest: compounds 1 and 4 (each within the scatter of the next); then compounds 2 and 3 (each within the scatter of the next).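

In this assay, the side chain on this aromatic carbon, next to the ring nitrogen, is exchanged while the amide group stays the same, and the result is a 1.2-fold higher number from compound 1 to compound 4 (0.08 log units; within the scatter). Going by these compounds alone, this is the first view of the side chain on its own: an open chain with no ring and 1 hydrogen-bond donor gives way to a group with a six-membered non-aromatic ring and 0 hydrogen-bond donors, and the two compounds cannot be told apart in this read-out. No evidence on any property of either side chain is available to account for this outcome.

Going by these compounds, this rests on a single pair carrying a single amide group, so it remains open whether the same exchange would also stay within the scatter with the 2-methylphenyl or 3-bromophenyl amide groups of compound 2 and compound 3. On these data alone, it also remains open how a morpholine ring, a piperazine without the isopropyl group or a carboxylic acid at this same position would compare with the 4-isopropylpiperazin-1-yl and (2-(diethylamino)ethyl)amino groups.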